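A few compounds are considered here, and "the series" means these few. Any claim that something is new, unique, unknown or untested is made for them only; others in the source may bear on it.

Compound 1 `O=C(/C=C/c1ccc(OCCCCO[N+](=O)[O-])c(O)c1)OCCCCO[N+](=O)[O-]` in a functional assay on NCI-H157 cells (Homo sapiens) for cytotoxicity, read by resazurin assay, with a stated time of 72 h (a higher number here means a weaker inhibitor, a lower number a stronger inhibitor), reaches only the limit of the assay, > 50000 nM.
Compound 2 `O=C(/C=C/c1ccc(OCCCCCCO[N+](=O)[O-])c(O)c1)OCCCCCCO[N+](=O)[O-]` in this assay likewise reaches only a limit, > 50000 nM.
Compound 3 `COc1cc(/C=C/C(=O)OCCCCO[N+](=O)[O-])ccc1OCCCCO[N+](=O)[O-]` in this assay also reaches only a limit, > 50000 nM.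

The three measured compounds share a cinnamate ester carrying two nitrooxyalkyl chains, one on the ester and one on a phenolic oxygen, and all three stop at the same limit; the difference between the cores of compound 1 and compound 2 is not broken down here. Compound 3 differs from compound 1 only by methyl in place of hydrogen on an oxygen on an aromatic ring. Because every value sits at the limit (the limit of > 50000 nM in this assay, at which 3 of the 3 values shown sit), the step that the two limits leave unreadable from compound 1 to compound 3 cannot be read: both ends are limits, so neither its size nor its direction is known.

The unmeasured compound 4 `COc1cc(/C=C/C(=O)OCCCCCCO[N+](=O)[O-])ccc1OCCCCCCO[N+](=O)[O-]` relates to compound 2 exactly as compound 3 relates to compound 1: methyl in place of hydrogen on an oxygen on an aromatic ring. The place is the same in both pairs, so this is the same change, made on the core of compound 2 instead of the core of compound 1.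

Within the data shown here, since the only measured instance of the change, from compound 1 to compound 3, left both partners at the limit, no size is available to transfer. The expectation for compound 4 therefore rests on the limits of compound 2 and compound 3 alone, and the step from compound 2 to compound 4 is expected to be a step that the limit leaves unreadable from compound 2 to compound 4. In this assay compound 4 is estimated at 80000 nM, with a range from 40000 nM to 200000 nM, most likely reported again as a limit.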

Compound 4, half-maximal inhibitory concentration: > 50000 nM
Compound 4: no number, only a limit (the forecaster's own chance of this, stated with the estimate: 90%); the middle value does not contradict the limit.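

Compound 4 in this assay gives > 50000 nM, which is a limit and not a number. No new step can be read from compound 2 to compound 4, because both ends are limits: the limit of > 50000 nM in this assay, at which 4 of the 4 values shown sit.

The compounds shown leave open where any of the four truly lies past that limit, and whether hydroxy to methoxy changes the read-out on either core.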